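Compound 3: a ring replaces the open side chain

A few compounds are considered here, and "the series" means these few. Any claim that something is new, unique, unknown or untested is made for them only; others in the source may bear on it.

- compound 1 (`COc1ccc(/C=C\c2cc(OC)c(OC)c(OC)c2)cc1OCc1ccc(CNCCN(C)C)cc1`) gives 1400 nM in a functional assay on MC-38 cells (Mus musculus) for antiproliferative activity, read by CCK-8 assay, with a stated time of 48 h; a higher number here means a weaker inhibitor, a lower number a stronger inhibitor
- compound 2 (`COc1ccc(/C=C\c2cc(OC)c(OC)c(OC)c2)cc1OCc1ccc(CNCCNC(C)=O)cc1`) gives 1800 nM in this assay

Compound 2 has only compound 1 to be compared with, and the two values cannot be ranked (a 1.3-fold higher number from compound 1 to compound 2 (0.11 log units; within the scatter)). Compound 3 (`COc1ccc(/C=C\c2cc(OC)c(OC)c(OC)c2)cc1OCc1ccc(CN2CC[C@@H](O)C2)cc1`) keeps the shared core but exchanges the side chain of compound 2 (3-hydroxypyrrolidin-1-yl in place of (2-acetamidoethyl)amino on a saturated chain carbon bound to an aromatic carbon). In words, 3-hydroxypyrrolidin-1-yl comes in place of (2-acetamidoethyl)amino on a saturated chain carbon bound to an aromatic carbon. Within the data shown here, the single measured step also altered this side chain, and it stayed within the scatter. Among the measured compounds shown here, no measured compound carries a ring here, so that step is only a loose guide. In this assay a step no larger than the scatter is therefore expected (a 1.2-fold lower number from compound 2 to compound 3 (0.08 log units; within the scatter)). Compound 3 is estimated at 1500 nM (expected range 500 nM to 4500 nM).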

Compound 3, half-maximal inhibitory concentration: 6900 nM
For compound 3 the middle estimate is 4.6-fold (0.66 log units) below the measured one; the measured number lies above the stated range.
By their numbers in this assay, from the lowest: compounds 1 and 2 (each within the scatter of the next); then compound 3.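

In this assay, the side chain on a saturated chain carbon bound to an aromatic carbon proves sensitive to change: replacing the open chain with 3-hydroxypyrrolidin-1-yl gives a 3.8-fold higher number from compound 2 to compound 3 (0.58 log units; beyond the scatter) and also a 4.9-fold higher number from compound 1 to compound 3 (0.69 log units; beyond the scatter), so compound 3 is the weaker inhibitor in both comparisons. Among these compounds, changing only the end of the open chain had stayed within the scatter, so this is the first change here that clearly shifts the result, though it is modest in size. No measurement shown here explains the shift.

The exchange brings in a ring and a hydroxyl together, so the compounds shown cannot say which of the two matters. A plain pyrrolidin-1-yl group, without the hydroxyl, or a six-membered piperidin-1-yl ring would help to separate these two features.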